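This account rests on a few compounds, and the source may have more. Where it says the series, first, only, none or still open, it means among the compounds named here.

Measured so far:

Compound 1 `c1ccc2c(c1)CC2CN1CCN(c2cccc3c2OCCO3)CC1`, which in an assay for activation of Adrenergic receptor alpha-1 (Rattus norvegicus) (on this read-out higher numbers stand for an effect only at larger amounts of compound and lower numbers for an effect already at smaller amounts), gives 0.7 mg/kg.
Compound 2 `Clc1cccc2c1CC2CN1CCN(c2cccc3c2OCCO3)CC1`, which in this assay gives 5 mg/kg.

Of the two numbers, compound 2 stands at the higher one. Among the compounds with values here, its only neighbour is compound 1, and the single step that separates them, chloro in place of hydrogen on an aromatic carbon, shows a 7.1-fold higher number from compound 1 to compound 2 (0.85 log units; beyond the scatter).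

Compound 3 `Fc1cccc2c1CC2CN1CCN(c2cccc3c2OCCO3)CC1` has not yet been measured. It differs from compound 2 in one place: fluoro in place of chloro on an aromatic carbon. Within the data shown here, the only measured step that bears on this is the one from compound 1 to compound 2, which describes what the chloro adds at this position relative to hydrogen. Among the measured compounds shown here, no measured pair shows a fluoro at this position, so the expectation rests on fluoro being counted as one heavy atom, as is chloro, while the hydrogen of compound 1 is the other end of the known step.

The number for compound 3 in this assay is therefore expected to fall somewhere between those of compound 1 and compound 2, that is, the expected step is a 2.5-fold lower number from compound 2 to compound 3 (0.40 log units; beyond the scatter), a modest move downward. Compound 3 is estimated at 2 mg/kg, with a range from 0.7 mg/kg to 6 mg/kg.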

Compound 3, dose for half-maximal effect: > 1.25 mg/kg
Compound 3: a limit, no number; the forecaster's own chance of this, stated with the estimate: 5%; the middle value is on the limit's open side.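

For compound 3, this assay returns a limit and not a number: the limit of > 1.25 mg/kg in this assay, at which 1 of the 3 values shown sits.

Within the data shown here, this is the first view of fluoro on this aromatic carbon, and against hydrogen it gives an at least 1.7-fold higher number from compound 1 to compound 3 (0.25 log units; that floor lies within the scatter), so the limit does not yet set fluoro apart from hydrogen at this position, although it leaves room for a larger step. Among these compounds, the change from chloro to fluoro cannot be read, so the compounds do not tell whether fluoro stands closer to hydrogen or to chloro, and the only readable step beyond the scatter at this position remains a 7.1-fold higher number from compound 1 to compound 2 (0.85 log units; beyond the scatter).

What a methoxy group, a nitrile or an amine on the same aromatic carbon would do in this assay remains open, so the compounds shown cannot say whether any group there can match the hydrogen of compound 1. Also open, from the compounds shown here alone, is where a true number for compound 3 would fall, and with it whether fluoro and chloro differ at all at this position.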